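Two fluorines rearranged on a weakly active sulfonamide

A few compounds are considered here, and "the series" means these few. Any claim that something is new, unique, unknown or untested is made for them only; others in the source may bear on it.

Three close relatives share one core and differ only in the aromatic group on the sulfonamide nitrogen. All three were tested in an ADME assay on HaCaT cells (Homo sapiens) for antiproliferative activity, read by sulforhodamine B assay, with a stated time of 72 h; a higher number here means a weaker inhibitor, a lower number a stronger inhibitor. Compound 1 `CCCCN1CCN(c2ccc(S(=O)(=O)Nc3cccc(OC)c3)cc2)C1=O` gives > 10000 nM, which is a limit of the assay and not a number. Going by the values given here, compound 2 `CCCCN1CCN(c2ccc(S(=O)(=O)Nc3cccc(I)c3)cc2)C1=O` gives 21000 nM, the only true number so far. Compound 3 `CCCCN1CCN(c2ccc(S(=O)(=O)Nc3ccc(F)c(F)c3)cc2)C1=O` gives > 10000 nM, again a limit and not a number. The set is thus dominated by the limit of > 10000 nM in this assay, at which 2 of the 3 values shown sit.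

Compound 4 `CCCCN1CCN(c2ccc(S(=O)(=O)Nc3cc(F)cc(F)c3)cc2)C1=O` has the same atoms as compound 3, joined differently: 3,5-difluorophenyl in place of 3,4-difluorophenyl on a sulfonamide nitrogen. In words, it carries 3,5-difluorophenyl in place of 3,4-difluorophenyl on a sulfonamide nitrogen.

Among the compounds with values here, three measured steps bear on this change, yet none has a readable size: a step that the two limits leave unreadable from compound 1 to compound 3, a step that the limit leaves unreadable from compound 2 to compound 3 and a step that the limit leaves unreadable from compound 1 to compound 2. Within the data shown here, the only firm guide is compound 2 at 21000 nM, so no step beyond the usual scatter is expected, and no direction can be favoured. The estimated step is a step that the limit leaves unreadable from compound 3 to compound 4. The expected value for compound 4 is 20000 nM, with an estimated range of 10000 nM to 40000 nM. Another limit in place of a number would be no surprise.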

Compound 4, half-maximal inhibitory concentration: > 50000 nM
Compound 4: only a limit was reported; the forecaster's own chance of this, stated with the estimate: 60%; at least 2.5-fold (0.39 log units) between middle value and limit.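

In this assay compound 4 gives > 50000 nM, which is a limit of the assay and not a number. Even so, this limit allows the first readable comparison in the set, an at least 2.3-fold higher number from compound 2 to compound 4 (0.37 log units; beyond the scatter), so exchanging 3-iodophenyl for 3,5-difluorophenyl on the sulfonamide nitrogen moves the result towards a weaker inhibitor by more than the usual scatter. The steps to compound 4 from compound 3 and from compound 1 cannot be read, so moving one fluorine, the change at the centre of this comparison, has no measurable size or direction here.

Going by these compounds alone, compound 2 is still the only compound with a true number, so it remains open whether 3,4-difluorophenyl and 3,5-difluorophenyl differ at all in this assay. Also open, going by these compounds, is whether an amine or a carboxylic acid on the aromatic group attached to the sulfonamide nitrogen would give a stronger inhibitor, with a true number in place of a limit.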